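This account rests on a few compounds, and the source may have more. Where it says the series, first, only, none or still open, it means among the compounds named here.

Compound 1 `COc1ccc(-c2cc3ccc(OC)cc3nc2Nc2ccc(NC(=O)CN3CCCCC3)cc2)cc1` and compound 2 `CCN(CC)CC(=O)Nc1ccc(Nc2nc3ccc(OC)cc3cc2-c2ccc(OC)cc2)cc1` share one core and differ only in the amine at the end of the amide side chain. In a functional assay on HUVEC cells (Homo sapiens) for antiproliferative activity, read by MTT assay, with a stated time of 48 h (on this read-out lower numbers stand for stronger inhibition and higher numbers for weaker inhibition), compound 1 gives 23500 nM, and in this assay compound 2 gives 45600 nM. Compound 2 thus has the higher of the two numbers, but the gap to compound 1 lies within the scatter of the measurement, so the two amines read as equivalent here. Compound 3 `COc1ccc(-c2cc3cc(OC)ccc3nc2Nc2ccc(NC(=O)CN3CCN(C)CC3)cc2)cc1` has not yet been measured. Relative to compound 2 it carries 4-methylpiperazin-1-yl in place of diethylamino on a saturated chain carbon bound to a carbonyl carbon. Among the compounds with values here, with no measured pair bracketing this change, and the two known amine variants indistinguishable in this assay, no step beyond the scatter is expected in either direction. For compound 3 the estimated result in this assay is 30000 nM, with a plausible range from 10000 nM to 90000 nM, meaning an expected step of a 1.5-fold lower number from compound 2 to compound 3 (0.18 log units; within the scatter).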

Compound 3, half-maximal inhibitory concentration: 7400 nM
The estimate for compound 3 lay 4.1-fold (0.61 log units) above the measured number, and the stated range ends above it.
By their numbers in this assay, from the lowest: compound 3; then compounds 1 and 2 (each within the scatter of the next).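

In this assay, placing 4-methylpiperazin-1-yl in place of diethylamino on a saturated chain carbon bound to a carbonyl carbon gives a 6.2-fold lower number from compound 2 to compound 3 (0.79 log units; beyond the scatter), a step beyond the scatter. Within the data shown here, this is the first one-place comparison, and it shows that the amine at this position is not indifferent to the read-out, with the ring-bearing amine giving the lower number of the pair. The change brings in a six-membered ring and a second nitrogen together, and nothing shown here accounts for the step.

Among these compounds, the single pair cannot separate the ring from the second nitrogen, which a morpholine or a piperazine without the methyl group would address. It also leaves open whether a pyrrolidine or a longer chain between the amide carbonyl and the amine would keep the step.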